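Two aryl tetrazole ketones and a thiophene analogue

The compounds below may be only part of what the source reports. "The series", "measured", "known", "first", "only" and "open" are said of these compounds alone.

Measured so far:
compound 1, `CCCCCCCCc1ccc(OCC(=O)Cn2nnnc2-c2ccccc2Cl)cc1`, 4600 nM
compound 2, `CCCCCCCCc1ccc(OCC(=O)Cn2nnnc2-c2ccccn2)cc1`, 880 nM

The two measured compounds share the same core and differ only in the aromatic group attached to it. In an assay on microsomes from brain for inhibition of Fatty-acid amide hydrolase 1 (Rattus norvegicus), read by fluorescence and HPLC, with a stated time of 60 min (a lower number here means a stronger inhibitor, a higher number a weaker inhibitor), compound 1 gives 4600 nM, while compound 2 gives 880 nM. Going by the values given here, the step of a 5.2-fold lower number from compound 1 to compound 2 (0.72 log units; beyond the scatter) shows that this exchange is the single observation available, and compound 2 stands as the lowest of the two numbers, with compound 1 as its only neighbour.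

Compound 3, `CCCCCCCCc1ccc(OCC(=O)Cn2nnnc2-c2cccs2)cc1`, has not yet been measured. It differs from compound 2 by thiophen-2-yl in place of pyridin-2-yl on an aromatic carbon. Among the compounds with values here, the only measured step that bears on this change is the one from compound 1 to compound 2, which involved a different pair of groups at the same position, so it gives only a loose guide to the size of an aryl exchange there. A modest move in either direction is plausible; a small weakening relative to compound 2 is expected, giving a 1.7-fold higher number from compound 2 to compound 3 (0.23 log units; within the scatter) in this assay. The estimate for compound 3 is 1500 nM, with a range from 500 nM to 5000 nM.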

Compound 3, half-maximal inhibitory concentration: 55 nM
Estimate against measurement, compound 3: 27-fold (1.44 log units) above; measured number below the stated range.
By their numbers in this assay, from the lowest: compound 3; then compound 2; then compound 1.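

In this assay the aromatic group on the shared core turns out to matter more than the first pair could show: thiophen-2-yl in place of pyridin-2-yl produces a large step (a 16-fold lower number from compound 2 to compound 3 (1.20 log units; beyond the scatter)), whereas the exchange between the first two compounds was only modest (a 5.2-fold lower number from compound 1 to compound 2 (0.72 log units; beyond the scatter)). Thiophen-2-yl in place of 2-chlorophenyl produces a large step as well (an 84-fold lower number from compound 1 to compound 3 (1.92 log units; beyond the scatter)), so compound 3 is the strongest inhibitor of the three, with its steps to both others beyond the scatter. No measurement given here accounts for the size of these steps.

Each exchange to thiophen-2-yl replaces a six-membered aromatic ring with a five-membered one and also brings in sulfur, so these three compounds cannot separate the effect of ring size from that of the hetero atom; furan-2-yl, thiophen-3-yl or a plain phenyl group at this place would bear on that question. Going by these compounds, the octyl chain is the same in all three compounds, so it also remains open whether the advantage of thiophen-2-yl would hold with a shorter chain.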